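The source may report more compounds than this note shows. Statements on the series, on what has been measured and on what is new or still open speak of the compounds shown alone.

Working notes on the series in an assay on cells (Endothelial cell) for binding affinity to Endothelin-1 receptor (Sus scrofa); a lower number here means a stronger inhibitor, a higher number a weaker inhibitor.

Among the measured compounds shown here, compound 3 `COc1cccc(Oc2c(NS(=O)(=O)c3ccc(C(C)(C)C)cc3)ncnc2OCCOc2ncccn2)c1` gives 1.9 nM and stands lowest of the three numbers measured so far. Compound 1 `COc1cccc(Oc2c(NS(=O)(=O)c3ccc(C(C)(C)C)cc3)ncnc2OCCO)c1` gives 160 nM, and compound 2 `COc1cccc(Oc2c(NS(=O)(=O)c3ccc(C(C)(C)C)cc3)ncnc2OCCOCc2ccccc2)c1` gives 170 nM. The measured steps are a 1.1-fold higher number from compound 1 to compound 2 (0.03 log units; within the scatter), an 84-fold lower number from compound 1 to compound 3 (1.93 log units; beyond the scatter) and an 89-fold lower number from compound 2 to compound 3 (1.95 log units; beyond the scatter): the two large steps both come from the group placed on the oxygen on a saturated carbon, while the benzyl for hydrogen exchange leaves the number where it was.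

Compound 4 `COc1cccc(Oc2c(NS(=O)(=O)c3ccc(C(C)(C)C)cc3)ncnc2OCCOc2nccc(C)n2)c1` differs from compound 3 by methyl in place of hydrogen on an aromatic carbon. For the measured compounds named here, none of the measured steps touches the pyrimidin-2-yl itself; they all exchange the whole group on that oxygen, so there is no direct precedent for a single methyl on the ring. With the entering group being one carbon and the rest of compound 3 kept, a step within the scatter is expected, in either direction. The step of a 1.2-fold higher number from compound 3 to compound 4 (0.06 log units; within the scatter) is expected to stay within the scatter. Compound 4 is therefore estimated at 2.2 nM, with a range from 0.8 nM to 6 nM.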

Compound 4, half-maximal inhibitory concentration: 39.4 nM
The estimate for compound 4 lay 18-fold (1.25 log units) below the measured number, outside the stated range (above it).
By their numbers in this assay, from the lowest: compound 3; then compound 4; then compounds 1 and 2 (each within the scatter of the next).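

In this assay, the pyrimidin-2-yl proves sensitive to a single added carbon: methyl on the aromatic carbon next to the ring nitrogen gives a 21-fold higher number from compound 3 to compound 4 (1.32 log units; beyond the scatter), so the ring itself matters and not only the choice of whole group on the oxygen. The 4-methylpyrimidin-2-yl still keeps part of the advantage over the other groups on that oxygen, with a 4.3-fold lower number from compound 2 to compound 4 (0.63 log units; beyond the scatter) and a 4.1-fold lower number from compound 1 to compound 4 (0.61 log units; beyond the scatter), both modest beside the large steps of the unsubstituted ring. No evidence is available that bears on the origin of the methyl step.

On these data alone, whether a chlorine, a methoxy or an ethyl on this same carbon would follow the methyl remains open. Also open, as far as these compounds go, is how a methyl on another carbon of the pyrimidin-2-yl would compare.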